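Swapping isopropyl for bromo on the aryl ring

The source may report more compounds than this note shows. Statements on the series, on what has been measured and on what is new or still open speak of the compounds shown alone.

Measured compounds:
compound 1, `CCN(C)c1cc(C)nc2c1NC(=O)CN2c1ccc(C(C)C)cc1Br`, 16.4 nM
compound 2, `CCCCN(CC)c1cc(C)nc2c1NC(=O)CN2c1ccc(Br)cc1Cl`, 2.7 nM
compound 3, `CCCCN(CC)c1cc(C)nc2c1NC(=O)CN2c1ccc(C(C)C)cc1Br`, 2.4 nM

In an assay on HEK-293T cells for displacement of a labelled ligand from corticotropin-releasing factor receptor 1 (Homo sapiens), read by scintillation counting, with a stated time of 2 h (on this read-out lower numbers stand for stronger inhibition and higher numbers for weaker inhibition), compound 3 sits at the low end of the three numbers, with compound 2 so close that the two cannot be told apart, while compound 1 stands clearly higher: a 6.8-fold lower number from compound 1 to compound 3 (0.83 log units; beyond the scatter), through propyl in place of hydrogen on a saturated chain carbon bound to a nitrogen on an aromatic ring.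

Compound 4, `CCCCN(CC)c1cc(C)nc2c1NC(=O)CN2c1ccc(Br)cc1Br`, differs from compound 3 in one place: bromo in place of isopropyl on an aromatic carbon. Going by the values given here, no measured step isolates this change. Among the compounds with values here, the only hint comes from compound 2, which differs from compound 3 in two places, bromo in place of isopropyl together with chloro in place of bromo, and gives a number within the scatter of compound 3. On that basis the expected step of a 1.3-fold higher number from compound 3 to compound 4 (0.10 log units; within the scatter) is small, with no clear direction. Compound 4 is therefore estimated at 3 nM, within 1.2 nM to 8 nM.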

Compound 4, inhibition constant: 1.3 nM
Compound 4: middle estimate off by 2.3-fold (0.36 log units), on the high side; the measured number falls inside the stated range.
By their numbers in this assay, from the lowest: compounds 4, 3 and 2 (each within the scatter of the next, the first and the last beyond it); then compound 1.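

In this assay, the step for bromo in place of isopropyl, a 1.8-fold lower number from compound 3 to compound 4 (0.27 log units; within the scatter), shows that this carbon, para to a large group, can carry a single bromine atom or the three-carbon isopropyl with no change that can be told from scatter. The other halogen exchange, bromo in place of chloro on an aromatic carbon, gives a modest step beyond the scatter, a 2.1-fold lower number from compound 2 to compound 4 (0.32 log units; beyond the scatter), so here the identity of a halogen on the ring does show in the number. Nothing available explains either step.

As far as these compounds go, whether a methoxy group, a nitrile or a plain hydrogen at the carbon that held isopropyl would keep the number this low remains open. So does whether bromo in place of isopropyl would give a similar step with the ethyl and methyl groups on the amine of compound 1.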